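The source may hold more compounds than are shown below. What is called first, only, known or untested is meant among the compounds shown, and "the series" means these compounds.

Measured compounds:

Compound 1, `N#C[Se]c1ccc(NC(=O)OCc2ccc([N+](=O)[O-])cc2)cc1`, gives 9300 nM in a functional assay on CCRF-CEM cells (Homo sapiens) for cytotoxicity, read by MTT assay, with a stated time of 72 h; a higher number here means a weaker inhibitor of growth, a lower number a stronger inhibitor of growth.
Compound 2, `N#C[Se]c1ccc(NC(=O)Oc2ccc(F)cc2)cc1`, gives 12600 nM in this assay.

Among the measured compounds shown here, only two compounds have been measured, and compound 2 carries the higher of the two numbers, but its number lies within the scatter of that of compound 1, so the two cannot be told apart on these data. Both carry the same selenocyanate-bearing core; they differ in what hangs on the other side of the carbamate, a nitrobenzyl group in compound 1 and a fluorophenyl group in compound 2.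

Compound 3, `COc1ccc(OC(=O)Nc2ccc([Se]C#N)cc2)cc1`, has not yet been measured. Its change from compound 2 is methoxy in place of fluoro on an aromatic carbon. For the measured compounds named here, no measured pair here shows what such an exchange does, so there is no step to lean on; the one measured pair shows two rather different groups at that end of the molecule giving numbers within the scatter of each other. On that ground, the step from compound 2 to compound 3 is expected to be small, a 1.1-fold lower number from compound 2 to compound 3 (0.02 log units; within the scatter), with no clear direction beyond the scatter. Compound 3 is therefore estimated at 12000 nM, within a range of 5000 nM to 30000 nM.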

Compound 3, concentration for 50% growth inhibition: 13000 nM
Compound 3: middle estimate off by 1.1-fold (0.03 log units), on the low side, and the stated range covers the measured number.
By their numbers in this assay, from the lowest: compounds 1, 2 and 3 (each within the scatter of the next).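

In this assay, the exchange of fluoro for methoxy on this aromatic carbon, para to a large group, gives a 1.0-fold higher number from compound 2 to compound 3 (0.01 log units; within the scatter). Among the compounds shown here, this is the first comparison that changes only one group, and it shows no difference that can be told from the scatter. Methoxy has more heavy atoms than fluoro and brings a hydrogen-bond acceptor that fluoro lacks, yet these differences between the two groups come with no readable difference in growth inhibition in this one cell assay, and nothing measured here offers an explanation for that.

For the compounds shown here, whether an amine, a carboxylic acid or a longer chain such as butoxy on this same carbon would give a number beyond the scatter of compound 2 remains open, so the flat result covers only this one exchange and cannot yet be called a rule for the position. The part played by the selenocyanate group in these numbers also remains open: every compound shown carries it.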